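Trifluoromethyl for Methyl on a Shared Amide Core

The compounds below may be only part of what the source reports. "The series", "measured", "known", "first", "only" and "open" are said of these compounds alone.

Compound 3 `Cc1ccc(C(=O)Nc2nc(Cl)c3cn(C(C)C)nc3n2)cc1` stands at the edge of what an assay on CHO cells for displacement of a labelled ligand from adenosine receptor A3 (Homo sapiens), read by scintillation counting, with a stated time of 3 h (a lower number here means a stronger inhibitor, a higher number a weaker inhibitor), can report: for compound 3 the assay gives only a limit, > 100000 nM. This is the point described by the limit of > 100000 nM in this assay, at which 1 of the 3 values shown sits. Where compound 3 carries methyl, compound 1 `CC(C)n1cc2c(Cl)nc(NC(=O)c3ccccc3)nc2n1` carries hydrogen, and compound 1 gives 12800 nM in this assay. Among the compounds with values here, the step of an at least 7.8-fold higher number from compound 1 to compound 3 (0.89 log units; beyond the scatter) is the one measured change at that position, and it runs toward weaker binding. Compound 2 `CC(C)(C)Cn1cc2c(Cl)nc(NC(=O)c3ccc(C(F)(F)F)cc3)nc2n1`, which carries trifluoromethyl on the six-membered aromatic ring of carbon only but a different alkyl group on the shared core, gives 6600 nM in this assay.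

Compound 4 `CC(C)n1cc2c(Cl)nc(NC(=O)c3ccc(C(F)(F)F)cc3)nc2n1` differs from compound 3 by trifluoromethyl in place of methyl on an aromatic carbon. Within the data shown here, the measured step shows that methyl at that position cost an at least 7.8-fold higher number from compound 1 to compound 3 (0.89 log units; beyond the scatter), and compound 2 shows that a trifluoromethyl at that position is compatible with a value of 6600 nM, though no single-change step connects compound 2 to compound 4. The expected direction for compound 4 is therefore toward a lower number, back near the level of compound 1 or compound 2. Compound 4 is estimated at 10000 nM, with a range from 3000 nM to 40000 nM, which means an expected step of an at least 10-fold lower number from compound 3 to compound 4 (1.00 log units; beyond the scatter).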

Compound 4, inhibition constant: 10300 nM
Compound 4: middle estimate off by 1.0-fold (0.01 log units), on the low side; measured number inside the range.
By their numbers in this assay, from the lowest: compounds 2, 4 and 1 (each within the scatter of the next). At a limit, above all of these: compound 3.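

In this assay the position para to a large group does not penalise every substituent: trifluoromethyl in place of methyl gives an at least 9.7-fold lower number from compound 3 to compound 4 (0.98 log units; beyond the scatter) and trifluoromethyl in place of hydrogen gives a 1.2-fold lower number from compound 1 to compound 4 (0.09 log units; within the scatter) so the loss seen with methyl does not extend to trifluoromethyl. Within the data shown here, compound 4 also gives the first direct reading of the alkyl group on the aromatic nitrogen, where isopropyl in place of neopentyl gives a 1.6-fold higher number from compound 2 to compound 4 (0.19 log units; within the scatter) and so, with trifluoromethyl on the ring, these two alkyl groups cannot be told apart in this assay. The size of the step away from methyl remains only a bound, since compound 3 is held at a limit: the limit of > 100000 nM in this assay, at which 1 of the 4 values shown sits.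

The compounds shown leave open whether other groups at this position, such as a nitrile, a methoxy group or a chlorine, behave like trifluoromethyl or like methyl, and whether methyl would carry the same cost with neopentyl on the aromatic nitrogen. They also leave open whether an amine in place of the chlorine on the shared core would move the number beyond the scatter.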